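The source may hold more compounds than are shown below. What is called first, only, known or untested is meant among the compounds shown, and "the series" means these compounds.

Measured compounds:
Compound 1, `COC(=O)c1cc(N)c(Nc2ccc(C#N)cc2)cc1Oc1c(C)cc(/C=C/C#N)cc1C`, in an ADME assay on TZM cells (Homo sapiens) for cytotoxicity, read by XTT assay, with a stated time of 4 days; on this read-out lower numbers stand for higher toxicity in this test and higher numbers for lower toxicity in this test: > 22800 nM
Compound 2, `Cc1cc(CCC#N)cc(C)c1Oc1cc(Nc2ccc(C#N)cc2)c(N)cc1C(=O)NN`, in this assay: > 22700 nM

The value for compound 1 is a limit of the assay, not a number. The value for compound 2 is also a limit of the assay and not a number, and it sits at the limit of > 22700 nM in this assay, at which 1 of the 2 values shown sits. Among the measured compounds shown here, compound 2 therefore stands where the only other value shown also stands: among values that are limits, with neither of the two compounds giving a measured number in this assay. For the measured compounds named here, no step between measured compounds can be drawn from this, so the two values show only that both are limits.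

Compound 3, `Cc1cc(CCC#N)cc(C)c1Oc1cc(Nc2ccc(C#N)cc2)c(N)cc1C(=O)O`, has not yet been measured. It differs from compound 2 in a single place: hydroxy in place of aminoamino on a carbonyl carbon. Going by the values given here, no measured step informs on this change, and the only values shown are limits. The step from compound 2 to compound 3 is therefore expected to be none beyond the scatter, a number no higher from compound 2 to compound 3 (the limit leaves the size open), with a further limit the most likely outcome. Compound 3 is accordingly expected to give about 22700 nM in this assay, within a range of 11000 nM to 50000 nM.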

Compound 3, half-maximal cytotoxic concentration: 14300 nM
Estimate against measurement, compound 3: 1.6-fold (0.20 log units) above, within the range that was stated.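

Among the compounds shown here, compound 3 is the first compound here to give a measured number rather than a limit in this assay, which shows that a change at this carbonyl carbon alone can leave a compound with a number inside the measured range. Replacing aminoamino with hydroxy, which cut one bond further out reads as aminocarbamoyl to carboxy, gives an at least 1.5-fold lower number from compound 2 to compound 3 (0.20 log units; that floor lies within the scatter), so the compounds do not establish a true difference between these two groups, although they do not rule one out. The true size of the step stays open, since the value of compound 2 is a limit and not a number: the limit of > 22700 nM in this assay, at which 1 of the 3 values shown sits.

The compounds shown do not tell whether the number of compound 3 follows from the hydroxy group that enters or from the loss of the aminoamino group, and they give no cause for the step. Going by these compounds, it also remains open whether a plain amino group or a methylamino group on the same carbonyl carbon would give a number close to that of compound 3 or another limit.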